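The compounds below may be only part of what the source reports. "The series", "measured", "known", "first", "only" and "open" are said of these compounds alone.

Measured so far:
compound 1, `Nc1nn(C(=O)Nc2ccc(Cc3ccccc3)cc2)c2ccccc12`: > 100000 nM
compound 2, `Nc1nn(C(=O)Nc2ccc(Cc3ccccc3)cc2)c2ccc(Cl)cc12`: 48200 nM

In a functional assay on OVCAR-3 cells (Homo sapiens) for antiproliferative activity, read by sulforhodamine B assay, with a stated time of 48 h (on this read-out higher numbers stand for lower toxicity in this test and lower numbers for higher toxicity in this test), compound 1 gives only a limit, > 100000 nM, and no number. Going by the values given here, compound 2 gives 48200 nM, the only number among the values shown. The remaining value, that of compound 1, sits at the limit of > 100000 nM in this assay, at which 1 of the 2 values shown sits. Among the compounds with values here, the one measured step, an at least 2.0-fold lower number from compound 1 to compound 2 (0.31 log units; beyond the scatter), is therefore bounded on one side only.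

Compound 3, `Nc1ccc2c(c1)c(N)nn2C(=O)Nc1ccc(Cc2ccccc2)cc1`, differs from compound 2 by amino in place of chloro on an aromatic carbon. Within the data shown here, no measured step exchanges chloro for amino, so the only guide is the step of chloro in place of hydrogen on an aromatic carbon, an at least 2.0-fold lower number from compound 1 to compound 2 (0.31 log units; beyond the scatter), which lowered the number by a modest amount. Taking the chloro away would be expected to undo that change, and the entering amino has no precedent in the series. Compound 3 is therefore expected to give a higher number than compound 2, a 2.1-fold higher number from compound 2 to compound 3 (0.32 log units; beyond the scatter), with a fair chance that only a limit is reported. Compound 3 is estimated at 100000 nM, within 40000 nM to 300000 nM.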

Compound 3, concentration lethal to 50% of the cells: 66700 nM
Compound 3: middle estimate off by 1.5-fold (0.18 log units), on the high side, within the range that was stated.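

Working from this assay, the aromatic carbon meta to a fused ring and para to a fused ring now has two groups to compare, and the exchange of chloro for amino does not separate them: a 1.4-fold higher number from compound 2 to compound 3 (0.14 log units; within the scatter). Set against the unsubstituted compound, the two groups are not equally well resolved, since the floor for chloro lies beyond the scatter, an at least 2.0-fold lower number from compound 1 to compound 2 (0.31 log units; beyond the scatter), while the floor for amino lies within it, an at least 1.4-fold lower number from compound 1 to compound 3 (0.17 log units; that floor lies within the scatter). Compound 1 gives > 100000 nM, which is a limit and not a number, so both steps from it remain floors with no upper bound: the limit of > 100000 nM in this assay, at which 1 of the 3 values shown sits.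

As far as these compounds go, the true size of the gain from either group therefore stays open, as does whether amino and chloro share that gain by chance or through a common effect. Also open, from the compounds shown here alone, is whether a different group on this carbon, such as a methoxy, a hydroxyl or a carboxylic acid, would give a number beyond the scatter of compound 2 and compound 3.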